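Swapping methylsulfanyl for fluoro on the anilide ring

The compounds below may be only part of what the source reports. "The series", "measured", "known", "first", "only" and "open" are said of these compounds alone.

Compound 1 `Cc1ccc(N2C(=O)C/C(=C\c3cccc(C(=O)Nc4cccc(F)c4)c3)C2=O)cc1`: in an ADME assay on SW480 cells (Homo sapiens) for cytotoxicity, read by MTT assay, with a stated time of 72 h (on this read-out higher numbers stand for weaker inhibition and lower numbers for stronger inhibition), compound 1 gives 96900 nM.
Compound 2 `Cc1cccc(NC(=O)c2cccc(/C=C3\CC(=O)N(c4ccccc4)C3=O)c2)c1`: in this assay compound 2 reaches only a limit, > 100000 nM.
Compound 3 `CSc1cccc(NC(=O)c2cccc(/C=C3\CC(=O)N(c4ccccc4)C3=O)c2)c1`: in this assay compound 3 gives 74300 nM.

Among these numbers compound 3 holds the lowest of the two numbers, but its nearest neighbour, compound 1, sits within the scatter of it, so no order between the two can be claimed. Compound 4 `O=C(Nc1cccc(F)c1)c1cccc(/C=C2\CC(=O)N(c3ccccc3)C2=O)c1` differs from compound 3 by fluoro in place of methylsulfanyl on an aromatic carbon. For the measured compounds named here, one measured step touches the same position: an at least 1.3-fold lower number from compound 2 to compound 3 (0.12 log units; that floor lies within the scatter), a change whose floor lies within the scatter, and it rests on a limit, (the limit of > 100000 nM in this assay, at which 1 of the 3 values shown sits). Going by the values given here, no measured step exchanges methylsulfanyl for fluoro, and compound 1, which carries the fluoro group, differs from compound 4 at a second place as well. The expectation for this assay is therefore a step of a 1.2-fold higher number from compound 3 to compound 4 (0.08 log units; within the scatter), within the scatter, with a real chance that compound 4 again reaches only the limit. Compound 4 is estimated at 90000 nM, between 45000 nM and 180000 nM.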

Compound 4, half-maximal inhibitory concentration: > 100000 nM
Compound 4: no number, only a limit; the forecaster's own chance of this, stated with the estimate: 35%; middle value at least 1.1-fold (0.04 log units) from the limit.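

Compound 4 reaches only a limit in this assay, > 100000 nM. The exchange of methylsulfanyl for fluoro now has a measured step, an at least 1.3-fold higher number from compound 3 to compound 4 (0.12 log units; that floor lies within the scatter), and hydrogen in place of methyl on an aromatic carbon, the second place of difference, gives an at least 1.0-fold higher number from compound 1 to compound 4 (0.01 log units; that floor lies within the scatter), so neither change is shown to go beyond the scatter. The step between the methyl and fluoro compounds at the first place cannot be read, and the limit now covers more of the series: the limit of > 100000 nM in this assay, at which 2 of the 4 values shown sit.

From the compounds shown here alone, how far compound 2 and compound 4 lie past that limit stays open, and with it any order among methyl, fluoro and methylsulfanyl at this position. Also open, going by these compounds, is whether an amine or a carboxylic acid at this place would give a number clearly lower than that of compound 3.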